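This account rests on a few compounds, and the source may have more. Where it says the series, first, only, none or still open, it means among the compounds named here.

Measured so far in an assay on a protein complex for displacement of a labelled ligand from CDK8/Cyclin C (Homo sapiens), read by TR-FRET, with a stated time of 1 h; a higher number here means a weaker inhibitor, a lower number a stronger inhibitor:
compound 1 `CNc1nccc(N2CC[C@H](NC(=O)Nc3ccc(Cl)c(C(F)(F)F)c3)C2)n1` — 10.1 nM
compound 2 `O=C(Nc1ccc(Cl)c(C(F)(F)F)c1)N[C@H]1CCN(c2ccnc(NC3CC3)n2)C1` — 20.3 nM
compound 3 `O=C(Nc1ccc(Cl)c(C(F)(F)F)c1)N[C@H]1CCN(c2ccncn2)C1` — 60.3 nM

Compound 1 holds the lowest number of the three; compound 2 sits within the scatter of it, a 2.0-fold higher number from compound 1 to compound 2 (0.30 log units; within the scatter), while compound 3 lies beyond it, a 6.0-fold higher number from compound 1 to compound 3 (0.78 log units; beyond the scatter).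

Compound 4 `CNc1nccc(N2CC[C@H](NC(=O)Nc3ccc(CN4CCCC4)c(C(F)(F)F)c3)C2)n1` is not yet measured. It differs from compound 1 on the aryl urea side: (pyrrolidin-1-yl)methyl in place of chloro on an aromatic carbon. The group enters ortho to a trifluoromethyl group and para to a large group.

Among the compounds with values here, none of the measured steps bears on this position; all three concern the substituent on a nitrogen on an aromatic ring of the shared core, and their sizes, a 2.0-fold higher number from compound 1 to compound 2 (0.30 log units; within the scatter) and a 3.0-fold higher number from compound 2 to compound 3 (0.47 log units; beyond the scatter), say nothing about the aryl ring. Within the data shown here, with no step to lean on, the expected change from compound 1 is no more than modest, in either direction. The estimated step is a 1.5-fold higher number from compound 1 to compound 4 (0.17 log units; within the scatter). For compound 4 the estimate in this assay is 15 nM, expected to fall between 4 nM and 60 nM.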

Compound 4, half-maximal inhibitory concentration: 157 nM
For compound 4 the middle estimate is 10-fold (1.02 log units) below the measured one; measured number outside the range, above it.
By their numbers in this assay, from the lowest: compounds 1 and 2 (each within the scatter of the next); then compound 3; then compound 4.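

This position on the aromatic carbon, ortho to a trifluoromethyl group and para to a large group, does not tolerate every replacement: in this assay, (pyrrolidin-1-yl)methyl in place of chloro gives a 16-fold higher number from compound 1 to compound 4 (1.19 log units; beyond the scatter), a large loss. With a single replacement shown here, the loss cannot be divided between the methylene, the ring nitrogen and the pyrrolidine ring. Nothing available here explains the step.

Still open, on these data alone, is whether a methyl, a dimethylaminomethyl or a morpholin-4-ylmethyl group here would stay closer to compound 1. Also open, as far as these compounds go, is whether the same replacement on compound 2 would cost as much.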